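This account rests on a few compounds, and the source may have more. Where it says the series, first, only, none or still open, it means among the compounds named here.

Working notes on the series in a functional assay on DU-145 cells (Homo sapiens) for antiproliferative activity, read by sulforhodamine B assay, with a stated time of 3 days; on this read-out higher numbers stand for weaker inhibition of growth and lower numbers for stronger inhibition of growth. Going by the values given here, compound 1 (`O=C(Nc1cccc(Nc2ncc(F)c(Nc3ccc(F)cc3)n2)c1)c1cnccn1`) gives 26400 nM and compound 2 (`O=C(Nc1cccc(Nc2ncc(F)c(Nc3ccc(F)cc3)n2)c1)c1cccc([N+](=O)[O-])c1`) gives 12600 nM, so compound 2 holds the lower of the two numbers so far. Compound 3 (`O=C(Nc1cccc(Nc2ncc(F)c(Nc3ccc(F)cc3)n2)c1)c1ccncc1`) is the next to be read and keeps the shared core of compound 2, with one change: pyridin-4-yl in place of 3-nitrophenyl on a carbonyl carbon. In words, this is pyridin-4-yl in place of 3-nitrophenyl on a carbonyl carbon.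

Among the compounds with values here, only one measured step bears on this change: a 2.1-fold lower number from compound 1 to compound 2 (0.32 log units; beyond the scatter), a modest step with 3-nitrophenyl in place of pyrazin-2-yl on a carbonyl carbon. Compound 3 loses the same 3-nitrophenyl and again carries a ring with hetero atoms there, so the closest measured reference is compound 1 at 26400 nM. Within the data shown here, no measured compound carries pyridin-4-yl, and a single step is thin support. In this assay a modest move toward a higher number is therefore expected, with the estimated step being a 2.1-fold higher number from compound 2 to compound 3 (0.31 log units; beyond the scatter). For compound 3 the estimated value is 26000 nM, with an expected range of 12000 nM to 55000 nM.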

Compound 3, concentration for 50% growth inhibition: 4330 nM
Beside the measured number, compound 3's estimate is 6.0-fold (0.78 log units) above it; the whole stated range lies above it.
By their numbers in this assay, from the lowest: compound 3; then compound 2; then compound 1.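

Working notes, continued: in this assay, the position on the carbonyl carbon does not sort by whether the ring has hetero atoms, as the first step alone might have suggested, since pyridin-4-yl in place of 3-nitrophenyl gives a 2.9-fold lower number from compound 2 to compound 3 (0.46 log units; beyond the scatter), whereas pyrazin-2-yl gives the highest number of the three. Between the two rings with hetero atoms, the change to pyridin-4-yl gives a 6.1-fold lower number from compound 1 to compound 3 (0.79 log units; beyond the scatter), so which such ring sits on the carbonyl carbon counts for more here than the mere presence of hetero atoms, with compound 2 and its carbon-only ring falling between the two. Nothing at hand explains this order.

The compounds shown leave open whether the gain belongs to the ring nitrogen of pyridin-4-yl as placed, which pyridin-3-yl or pyridin-2-yl on the same carbonyl carbon would test. They also leave open how an unsubstituted phenyl, or a phenyl carrying an amine in place of the nitro group, would stand against compound 2 and compound 3.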